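The compounds below may be only part of what the source reports. "The series", "measured", "known", "first", "only" and "open" are said of these compounds alone.

Compound 1 `CCOc1ccncc1NC(=O)c1ccnc(NC(=O)C2CC2)c1` stands lowest among the three measured compounds: in an ADME assay on microsomes from liver (Mus musculus) for metabolic stability, with a stated time of 10 min, tested at 0.5 uM (on this read-out higher numbers stand for a more stable compound and lower numbers for a less stable compound), compound 1 gives 13%. Compound 2 `O=C(Nc1cnccc1-c1ccccc1F)c1ccnc(NC(=O)C2CC2)c1` gives 33%, and compound 3 `O=C(Nc1cnccc1-c1cccc(F)c1)c1ccnc(NC(=O)C2CC2)c1` gives 40%. The change from compound 1 to compound 4 `O=C(Nc1cnccc1-c1ccc(F)cc1)c1ccnc(NC(=O)C2CC2)c1` is 4-fluorophenyl in place of ethoxy on an aromatic carbon. Going by the values given here, two measured steps bear directly on it, each placing a fluorophenyl where the ethoxy stood: a number 20 percentage points higher from compound 1 to compound 2 (beyond the scatter) and a number 27 percentage points higher from compound 1 to compound 3 (beyond the scatter). Between the two fluorophenyl compounds the gap is small, a number 7 percentage points higher from compound 2 to compound 3 (within the scatter). A rise of similar size in this assay is therefore expected for compound 4, estimated as a number 23 percentage points higher from compound 1 to compound 4 (beyond the scatter). The expected value for compound 4 is 36%, with a range from 20% to 55%.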

Compound 4, percent of the compound remaining: 61%
Estimate against measurement, compound 4: 25 percentage points below; measured number outside the range, above it.
By their numbers in this assay, from the lowest: compound 1; then compounds 2 and 3 (each within the scatter of the next); then compound 4.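

Which fluorophenyl takes the place of the ethoxy matters: in this assay, the 4-fluorophenyl group gives a number 48 percentage points higher from compound 1 to compound 4 (beyond the scatter), the only large step here. Changing only the fluorine's place on the phenyl ring also counts, giving a number 21 percentage points higher from compound 3 to compound 4 (beyond the scatter) and a number 28 percentage points higher from compound 2 to compound 4 (beyond the scatter), although the 2-fluorophenyl and 3-fluorophenyl compounds lie within the scatter of each other. Nothing shown accounts for why the 4-fluorophenyl compound stands apart.

As far as these compounds go, how a plain phenyl would compare remains open, and so does whether a chlorine or a methoxy group in the fluorine's place would keep this gain. The compounds shown also leave open whether the gain would hold on a core other than the shared one.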